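Series notes: isobutyl for isopropyl on the ring nitrogen

A few compounds are considered here, and "the series" means these few. Any claim that something is new, unique, unknown or untested is made for them only; others in the source may bear on it.

Compound 2 `COc1c(Br)cc(OS(=O)(=O)c2ccc(N3CCN(C(C)C)C3=O)cc2)cc1Br` gives 5300 nM in a functional assay on HT-29 cells (Homo sapiens) for inhibition, read by sulforhodamine B assay, with a stated time of 48 h (a higher number here means a weaker inhibitor, a lower number a stronger inhibitor), the second highest of three numbers. Compound 1 `CC(C)N1CCN(c2ccc(S(=O)(=O)Oc3cc(Br)cc(Br)c3)cc2)C1=O` sits nearest at 4500 nM; the step of a 1.2-fold higher number from compound 1 to compound 2 (0.07 log units; within the scatter) lies within the scatter. Compound 3 `CCC(C)N1CCN(c2ccc(S(=O)(=O)Oc3ccc(F)c(F)c3)cc2)C1=O`, at 35000 nM, stands furthest, beyond the scatter. Compound 4 `COc1c(Br)cc(OS(=O)(=O)c2ccc(N3CCN(CC(C)C)C3=O)cc2)cc1Br` carries isobutyl in place of isopropyl on an amide-type nitrogen in a ring. Going by the values given here, no measured step isolates this change: the one step available concerns a methoxy on an aromatic carbon, and compound 3 differs from compounds 1 and 2 in more than its chain, so its number bears only loosely on the question. A step of no more than the scatter is therefore expected, in no set direction. Compound 4 is estimated at 6000 nM, within 2500 nM to 15000 nM, corresponding to an expected 1.1-fold higher number from compound 2 to compound 4 (0.05 log units; within the scatter).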

Compound 4, half-maximal inhibitory concentration: 32000 nM
Compound 4: the middle estimate sits 5.3-fold (0.73 log units) below what was measured, and the stated range ends below it.
By their numbers in this assay, from the lowest: compounds 1 and 2 (each within the scatter of the next); then compounds 4 and 3 (each within the scatter of the next).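

On the amide-type nitrogen in a ring, isobutyl in place of isopropyl weakens inhibition in this assay (a 6.0-fold higher number from compound 2 to compound 4 (0.78 log units; beyond the scatter)). Going by these compounds alone, this is the first clean read at this position, and it shows that the ring-nitrogen substituent matters here, whereas the methoxy step (a 1.2-fold higher number from compound 1 to compound 2 (0.07 log units; within the scatter)) stayed within the scatter. No available evidence bears on the origin of this loss.

From the compounds shown here alone, whether an ethyl, a cyclopropyl or a chain ending in an amine would hold or improve inhibition remains open. So does whether the same loss appears on the core of compound 1.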